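Replacing a cyanophenyl group with a methylpyrazole

A few compounds are considered here, and "the series" means these few. Any claim that something is new, unique, unknown or untested is made for them only; others in the source may bear on it.

compound 1 `O=c1nc(-c2ccccc2)c2cc(-c3cccc(F)c3)ccc2[nH]1`: 23000 nM
compound 2 `O=c1nc(-c2ccccc2)c2cc(-c3ccc(F)cc3)ccc2[nH]1`: 50000 nM
compound 3 `N#Cc1ccc(-c2ccc3[nH]c(=O)nc(-c4ccccc4)c3c2)cc1`: > 50000 nM

These values come from an ADME assay on L6 cells (Rattus norvegicus) for cytotoxicity, read by fluorescence and resazurin assay, with a stated time of 72 h; a higher number here means that more compound is needed for the effect, a lower number that less compound is needed. Compound 3 has only a limit, > 50000 nM, and not a number. That is the limit of > 50000 nM in this assay, at which 1 of the 3 values shown sits.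

Compound 4 `Cn1cc(-c2ccc3[nH]c(=O)nc(-c4ccccc4)c3c2)cn1` carries 1-methyl-1H-pyrazol-4-yl in place of the 4-cyanophenyl of compound 3 (1-methyl-1H-pyrazol-4-yl in place of 4-cyanophenyl on an aromatic carbon). The measured steps that bear on this change are all swaps at the same place, but each one keeps a phenyl ring: a 2.2-fold higher number from compound 1 to compound 2 (0.34 log units; beyond the scatter), an at least 2.1-fold higher number from compound 1 to compound 3 (0.33 log units; beyond the scatter) and a number no lower from compound 2 to compound 3 (the limit leaves the size open). The first two are modest, and the size of the third cannot be read. None of them removes the phenyl ring, so they are only a loose guide. A modest move to a lower number is expected, with compound 1 at 23000 nM as the nearest measured reference. The expected change is an at least 1.5-fold lower number from compound 3 to compound 4 (0.19 log units; that floor lies within the scatter). For compound 4 the estimate is 32000 nM, with an expected range of 11000 nM to 65000 nM.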

Compound 4, half-maximal effective concentration: > 50000 nM
Compound 4 ended at the assay's limit; the forecaster's own chance of this, stated with the estimate: 35%; middle value at least 1.5-fold (0.19 log units) away from the limit.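

For the compounds shown here, compound 4 shows that this position can carry a five-membered aromatic ring in place of a phenyl ring, which none of the earlier compounds tested. In this assay, going by these compounds alone, the one step whose size can be read is an at least 2.1-fold higher number from compound 1 to compound 4 (0.33 log units; beyond the scatter), so the 1-methyl-1H-pyrazol-4-yl compound needs more compound for the effect than the 3-fluorophenyl compound does. A further step shows a number no lower from compound 2 to compound 4 (the limit leaves the size open). The step from compound 3 to compound 4 cannot be read, and compound 4, like compound 3, gives only a limit and not a number: the limit of > 50000 nM in this assay, at which 2 of the 4 values shown sit.

On these data alone, how far compound 3 and compound 4 lie from each other therefore stays open. So does how this position would respond to a pyrazole without the methyl group, or to a phenyl ring carrying an amine or a carboxylic acid.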